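A (2-Hydroxyethyl)amino Group Gives Way to Chloro

The source may hold more compounds than are shown below. What is called first, only, known or untested is meant among the compounds shown, and "the series" means these compounds.

Compound 3 (`OCCNc1[nH]ccc2ncnc1-2`) carries a (2-hydroxyethyl)amino group on the shared core. In a functional assay on EL4 cells (Mus musculus) for inhibition, tested at 100 uM (a higher number here means more inhibition at the concentration tested (going by the name of the read-out), a lower number less inhibition), compound 3 gives only a limit of the assay, < 5%. Compound 1 (`CNc1[nH]ccc2ncnc1-2`) also gives a limit in this assay, < 5%. Compound 2 (`[N-]=[N+]=Nc1[nH]ccc2ncnc1-2`) likewise gives a limit in this assay, < 5%. Because of the limit of < 5% in this assay, at which 3 of the 3 values shown sit, the steps a step that the two limits leave unreadable from compound 1 to compound 2, a step that the two limits leave unreadable from compound 1 to compound 3 and a step that the two limits leave unreadable from compound 2 to compound 3 have no readable size. Compound 4 (`Clc1[nH]ccc2ncnc1-2`) differs from compound 3 in one place: chloro in place of (2-hydroxyethyl)amino on an aromatic carbon. Within the data shown here, no measured step of readable size bears on this change, so no movement beyond the scatter is expected in either direction. Compound 4 is estimated at 3%, between 0% and 15%, in this assay, an expected step that the limit leaves unreadable from compound 3 to compound 4.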

Compound 4, a percentage reported as inhibition, at one concentration (the size of the read-out at that concentration, not a potency): < 5%
Compound 4: only a limit was reported (the forecaster's own chance of this, stated with the estimate: 70%); the middle value does not contradict the limit.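

No step from compound 1, compound 2 or compound 3 to compound 4 can be read, because all of these compounds sit at the same limit: the limit of < 5% in this assay, at which 4 of the 4 values shown sit.

The compounds shown leave open whether any group at this place on the shared core gives readable inhibition in this assay.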